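Two Thiazole Ureas Measured, a Third to Be Estimated

The compounds below may be only part of what the source reports. "The series", "measured", "known", "first", "only" and "open" are said of these compounds alone.

Of the compounds shown here, two built on the same core have been tested in a functional assay on MCF7 cells (Homo sapiens) for inhibition, read by MTT assay, with a stated time of 72 h; a higher number here means a weaker inhibitor, a lower number a stronger inhibitor. Compound 1 `CN(C(=O)NC(=O)c1ccc(Cl)cc1Cl)c1nc(C(F)(F)F)c(C(=O)N/N=C/c2ccc(C(F)(F)F)cc2)s1` gives 8.42 ug/mL in this assay. Compound 2 `CN(C(=O)NC(=O)c1ccccc1F)c1nc(C(F)(F)F)c(C(=O)N/N=C/c2cc(C(F)(F)F)cc(C(F)(F)F)c2)s1` gives 6.16 ug/mL in this assay, the lower of the two numbers, though its gap to compound 1 lies within the usual scatter, so the two cannot be told apart. Compound 1 and compound 2 differ in more than one place, so no single change accounts for the small gap between them.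

Compound 3 `CN(C(=O)NC(=O)c1cccc(C(F)(F)F)c1)c1nc(C(F)(F)F)c(C(=O)N/N=C/c2cc(C(F)(F)F)cc(C(F)(F)F)c2)s1` follows from compound 2 by one change: 3-(trifluoromethyl)phenyl in place of 2-fluorophenyl on a carbonyl carbon. Going by the values given here, no pair of measured compounds isolates this change, so there is no measured step to lean on. Among the compounds with values here, with only that gap between compound 1 and compound 2 as a guide, the expectation is that compound 3 will land close to compound 2, with any shift from compound 2 to compound 3 staying within the scatter. The expected step is a 1.1-fold higher number from compound 2 to compound 3 (0.02 log units; within the scatter). Compound 3 is therefore estimated at 6.5 ug/mL in this assay, with a plausible range from 3 ug/mL to 14 ug/mL.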

Compound 3, half-maximal inhibitory concentration: 6.08 ug/mL
The estimate for compound 3 lay 1.1-fold (0.03 log units) above the measured number; the measured number falls inside the stated range.
By their numbers in this assay, from the lowest: compounds 3, 2 and 1 (each within the scatter of the next).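

In this assay, putting 3-(trifluoromethyl)phenyl in place of 2-fluorophenyl on the carbonyl carbon gives a 1.0-fold lower number from compound 2 to compound 3 (0.01 log units; within the scatter), and this is the first pair shown that isolates a single change at this place. The entering group has 10 heavy atoms against 7 for the group that leaves, and its substituent is a trifluoromethyl rather than a fluorine, yet compound 2 and compound 3 cannot be told apart, so for this pair the place tolerates the exchange without a readable shift in the number. Nothing available explains why the exchange leaves the reading within the scatter.

Every group on this carbonyl carbon in the compounds shown is a phenyl ring carrying fluorine, chlorine or trifluoromethyl, so it remains open whether a ring bearing an amine or a carboxylic acid, or a longer alkyl chain in place of the ring, would move the number beyond the scatter. Going by these compounds, it is also open whether the same exchange would behave alike in compound 1, which differs from compound 2 in more than one place.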